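The source may report more compounds than this note shows. Statements on the series, on what has been measured and on what is new or still open speak of the compounds shown alone.

Working notes on the series. Compound 2 `CCC(=O)N1c2ccccc2CCC1C(=O)Nc1ccccc1C(F)(F)F` is the point of departure. In a functional assay on ACHN cells (Homo sapiens) for cytotoxicity, read by sulforhodamine B assay, with a stated time of 72 h (on this read-out higher numbers stand for weaker inhibition of growth and lower numbers for stronger inhibition of growth), compound 2 gives > 80000 nM, which is a limit of the assay and not a number. Compound 1 `CCCC(=O)N1c2ccccc2CCC1C(=O)Nc1ccccc1C(F)(F)F` carries a butanoyl group on the ring nitrogen in place of the propanoyl of compound 2; in this assay compound 1 gives > 70000 nM, again a limit. Compound 3 `O=C(Nc1ccc(O)cc1)C1CCc2ccccc2N1` has a hydrogen on the ring nitrogen and a hydroxyphenyl on the amide; in this assay compound 3 gives > 100000 nM, also a limit. Every value recorded so far is therefore a limit, as the limit of > 100000 nM in this assay, at which 1 of the 3 values shown sits, the limit of > 70000 nM in this assay, at which 1 of the 3 values shown sits, and the limit of > 80000 nM in this assay, at which 1 of the 3 values shown sits, show, and compound 2 stands among them with no number of its own.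

Compound 4 `CC(=O)N1c2ccccc2CCC1C(=O)Nc1ccccc1C(F)(F)F` is the next member. Among the compounds with values here, it differs from compound 2 by hydrogen in place of methyl on a saturated chain carbon bound to a carbonyl carbon, the same kind of shortening of the acyl chain as in the only measured step of that kind, a step that the two limits leave unreadable from compound 1 to compound 2, whose size the two limits leave unreadable. Within the data shown here, no measured step in this assay gives a direction for this change, and the three limits give no sign that a shortening by one methyl carries the series into the readable range. Compound 4 is therefore expected to sit near the limit again, with a step that the limit leaves unreadable from compound 2 to compound 4 as the expected step; the estimate for compound 4 is 100000 nM, within 30000 nM to 300000 nM.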

Compound 4, concentration for 50% growth inhibition: > 80000 nM
Compound 4: no number, only a limit (the forecaster's own chance of this, stated with the estimate: 85%); the middle value lies beyond the limit too.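

In this assay compound 4 gives > 80000 nM, which is a limit of the assay and not a number. Compound 1 and compound 2 also stand only at limits, so the steps linking them to compound 4 cannot be read. The compounds shown leave open whether any member of this series reaches a readable value in this assay.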